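The source may hold more compounds than are shown below. What is called first, only, known or untested is meant among the compounds shown, and "the series" means these compounds.

Measured compounds:
- compound 1, `COc1cccnc1Nc1cc2[nH]c(-c3cccc(C(F)(F)F)c3)nc2cn1`: 80%
- compound 2, `FC(F)(F)c1cccc(-c2nc3cnc(Nc4cnccn4)cc3[nH]2)c1`: 7%
- compound 3, `FC(F)(F)c1cccc(-c2nc3cnc(Nc4cccnn4)cc3[nH]2)c1`: 51%

In an ADME assay on microsomes from liver (Mus musculus) for metabolic stability, read by LC-MS, with a stated time of 30 min, tested at 0.1 uM (on this read-out higher numbers stand for a more stable compound and lower numbers for a less stable compound), compound 1 stands highest of the three. The nearest of the others is compound 3, with a number 29 percentage points lower from compound 1 to compound 3 (beyond the scatter), and the furthest is compound 2, with a number 73 percentage points lower from compound 1 to compound 2 (beyond the scatter). Between those two, a number 44 percentage points higher from compound 2 to compound 3 (beyond the scatter).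

The unmeasured compound 4, `Fc1cnc(Nc2cc3[nH]c(-c4cccc(C(F)(F)F)c4)nc3cn2)c(F)c1`, keeps the shared core of compound 1 and changes only the ring that hangs on the nitrogen on the aromatic ring: 3,5-difluoropyridin-2-yl in place of 3-methoxypyridin-2-yl on a nitrogen on an aromatic ring

Among the measured compounds shown here, no measured step swaps in a fluorine-bearing ring, so none bears directly on this change. What the three steps do show is that every replacement of the 3-methoxypyridin-2-yl group so far lowered the read-out in this assay, by a modest to large amount. A lowering of some size is therefore expected here too, though smaller than the large drop to compound 2, since compound 4 keeps a pyridin-2-yl ring. The expected step is a number 22 percentage points lower from compound 1 to compound 4 (beyond the scatter). For compound 4 the estimate in this assay is 58%, with a range from 35% to 82%.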

Compound 4, percent of the compound remaining: 49%
Beside the measured number, compound 4's estimate is 9 percentage points above it; low and high end bracket the measured number.
By their numbers in this assay, from the lowest: compound 2; then compounds 4 and 3 (each within the scatter of the next); then compound 1.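

In this assay, swapping 3-methoxypyridin-2-yl for 3,5-difluoropyridin-2-yl costs much of the stability of compound 1 (a number 31 percentage points lower from compound 1 to compound 4 (beyond the scatter)). Keeping a pyridin-2-yl ring on the nitrogen is therefore not enough on its own to hold the high number, and 3-methoxypyridin-2-yl remains the best of the four groups at this position. The new ring and pyridazin-3-yl cannot be told apart (a number 2 percentage points lower from compound 3 to compound 4 (within the scatter)), while the new ring reads far better than pyrazin-2-yl (a number 42 percentage points higher from compound 2 to compound 4 (beyond the scatter)).

No available evidence accounts for these differences between the rings. On these data alone, it also remains open how a plain pyridin-2-yl ring would read, or one carrying an amine or an ethoxy chain in place of the methoxy group.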